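A longer chain on the amine, with and without the sugar

The compounds below may be only part of what the source reports. "The series", "measured", "known", "first", "only" and "open" are said of these compounds alone.

Of the compounds shown here, three have been measured in a functional assay (Homo sapiens) for inhibition of Nucleic Acid, tested at 100 uM; on this read-out lower numbers stand for less inhibition and higher numbers for more inhibition at the one concentration tested (going by the name of the read-out). Compound 1 `CCCCCCNc1[nH]ccc2ncnc1-2` carries a hexylamino group on its core, and in this assay compound 1 gives 53%. Compound 2 `CNc1[nH]ccc2ncnc1-2` carries a methylamino group on the same core, and in this assay compound 2 gives 18%. The two differ in one place: pentyl in place of hydrogen on a saturated chain carbon bound to a nitrogen on an aromatic ring. That single change made a number 35 percentage points higher from compound 2 to compound 1 (beyond the scatter), a step well beyond the usual scatter of this kind of measurement.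

Compound 3 `CNc1nccc2c1ncn2C1O[C@H](CO)[C@@H](O)[C@H]1O` also carries a methylamino group, but on a different core that bears a sugar; how the two cores differ is not broken down here. In this assay compound 3 gives 8%. Its gap to compound 2 lies within the scatter, while compound 1 sits well beyond it.

Compound 4 `CCCCCCNc1nccc2c1ncn2C1O[C@H](CO)[C@@H](O)[C@H]1O` has not yet been measured. It stands to compound 3 as compound 1 stands to compound 2: pentyl in place of hydrogen on a saturated chain carbon bound to a nitrogen on an aromatic ring. This is the same change at the same place, occurring twice among these compounds, once measured and once not. Compound 4 is expected to gain a number 27 percentage points higher from compound 3 to compound 4 (beyond the scatter). That expectation rests on a single earlier example, because the same change gave a number 35 percentage points higher from compound 2 to compound 1 (beyond the scatter). Some caution is due, since that example comes from the other core and compound 3 starts from a low number. Compound 4 is therefore estimated at 35%, with a likely range from 15% to 55%.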

Compound 4, a percentage reported as inhibition, at one concentration (the size of the read-out at that concentration, not a potency): 8%
Compound 4: middle estimate off by 27 percentage points, on the high side; measured number below the stated range.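

On the core that bears a sugar, in this assay, replacing methylamino with hexylamino gave no change at the digits printed from compound 3 to compound 4 (within the scatter), so the gain seen on the other core did not carry across. Set side by side, the same change behaves differently on the two cores: the same change on two cores in this assay, a number 35 percentage points higher (beyond the scatter) from compound 2 to compound 1 and no change at the digits printed (within the scatter) from compound 3 to compound 4, 35 percentage points apart, beyond the scatter of two such steps. Within the data shown here, this shows that, for these four compounds, a step measured on one core could not be used to predict the step on the other; it does not show what lies behind the difference, whether the sugar or some other feature of the cores, and with only one pair on each core it sets no rule for the wider series.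

The compounds shown leave open how the read-out follows chain length on either core, since a propyl chain, a butyl chain or a chain longer than hexyl would show whether the gain on the core without the sugar builds gradually and whether any such chain gives a gain on the core with the sugar. They also leave open what happens when the sugar gives way to a simple methyl group, or when an amine or a carboxylic acid is placed at the end of the chain.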